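A few compounds are considered here, and "the series" means these few. Any claim that something is new, unique, unknown or untested is made for them only; others in the source may bear on it.

Measured in a functional assay on HCT-15 cells (Homo sapiens); a higher number here means that more compound is needed for the effect, a lower number that less compound is needed:
compound 1 `COc1cc(C2OC(c3ccc(N(C)C)cc3)=NN2C(C)=O)cc(OC)c1OC` gives 0.033 uM
compound 2 `COc1cc(C2OC(c3ccc(N(C)C)cc3)=NN2C=O)cc(OC)c1OC` gives 0.096 uM
compound 3 `COc1cc(C2OC(c3ccc(N(C)C)cc3)=NN2C(=O)CN=[N+]=[N-])cc(OC)c1OC` gives 0.15 uM

Compound 3, at 0.15 uM, cannot be separated from compound 2, given a 1.6-fold higher number from compound 2 to compound 3 (0.19 log units; within the scatter). It does stand apart from compound 1, with a 4.5-fold higher number from compound 1 to compound 3 (0.66 log units; beyond the scatter), and compound 1 has the lowest number of the three.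

The next compound is compound 4 `COc1cc(C2OC(c3ccc(N(C)C)cc3)=NN2C(=O)CN(C)C)cc(OC)c1OC`, with dimethylamino in place of azido on a saturated chain carbon bound to a carbonyl carbon. Among the measured compounds shown here, no measured step makes this exchange directly, so the evidence is indirect. The steps at this carbonyl carbon are a 2.9-fold higher number from compound 1 to compound 2 (0.46 log units; beyond the scatter) and a 4.5-fold higher number from compound 1 to compound 3 (0.66 log units; beyond the scatter), both modest, along with the step within the scatter already noted for compound 2 and compound 3. Nothing yet shows how dimethylamino itself behaves at this place, so the range has to stay wide.

On these three modest or smaller steps, no shift beyond the scatter is expected in this assay. The expected step is a 1.3-fold higher number from compound 3 to compound 4 (0.12 log units; within the scatter), in the direction of a slightly higher number. The estimated value for compound 4 is 0.2 uM, with an expected range from 0.06 uM to 0.6 uM.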

Compound 4, concentration for half-maximal effect: 80 uM
For compound 4 the middle estimate is 400-fold (2.60 log units) below the measured one, outside the stated range (above it).
By their numbers in this assay, from the lowest: compound 1; then compounds 2 and 3 (each within the scatter of the next); then compound 4.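

In this assay, among the compounds shown here, the saturated chain carbon bound to a carbonyl carbon proves far more sensitive to the group it carries than the earlier compounds suggested: azido and dimethylamino match in heavy-atom count, hydrogen-bond donors and acceptors and net charge, yet the exchange gives a 530-fold higher number from compound 3 to compound 4 (2.73 log units; beyond the scatter). The earlier changes on this carbonyl carbon were modest or within the scatter, while compound 4 stands well apart from both smaller analogues, with an 830-fold higher number from compound 2 to compound 4 (2.92 log units; beyond the scatter) and a 2400-fold higher number from compound 1 to compound 4 (3.38 log units; beyond the scatter), so a matching count of heavy atoms does not predict the outcome at this place. Nothing available bears on the origin of this large step.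

Going by these compounds, it remains open whether the sharp rise in the number belongs to dimethylamino alone or extends to other amines on this chain carbon, such as a primary amine or a diethylamino group. On these data alone, how a hydroxyl group, a carboxylic acid or a longer chain carrying dimethylamino would read in this assay also remains open.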